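Swapping a ring nitrogen for carbon: a lipophilicity estimate

The source may report more compounds than this note shows. Statements on the series, on what has been measured and on what is new or still open speak of the compounds shown alone.

Measured so far:
- compound 1 `CC[C@@H](Nc1c(C#N)c(-c2ccc(-c3ncccc3C)cc2)nc2cnccc12)C(N)=O`: 2
- compound 2 `CCOc1ccccc1-c1ccc(-c2nc3cnccc3c(N[C@H](CC)C(=O)NS(C)(=O)=O)c2C#N)cc1`: 2.2
- compound 3 `CCOc1ccccc1-c1ccc(-c2nc3cnccc3c(N[C@H](CC)C(=O)O)c2C#N)cc1`: 2.1

In a physicochemical assay for lipophilicity, read by HPLC, at pH 7.5 (on this read-out higher numbers stand for higher lipophilicity and lower numbers for lower lipophilicity), compound 1 gives 2, the lowest of the three numbers, though its gap to compound 3 and to compound 2 both fall within the scatter, so the three cannot be ranked. Among the compounds with values here, the one measured step, a number 0.10 log units lower from compound 2 to compound 3 (within the scatter), concerns the end of the side chain and lies within the scatter.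

Compound 4 `CC[C@@H](Nc1c(C#N)c(-c2ccc(-c3ccccc3C)cc2)nc2cnccc12)C(N)=O` differs from compound 1 in one place: 2-methylphenyl in place of 3-methylpyridin-2-yl on an aromatic carbon. Within the data shown here, no measured step touches this kind of change, so no direct guide exists within the data. A ring that carried one hydrogen-bond acceptor is replaced by one of carbon only, and from general experience with this assay such a replacement is expected to raise the read-out by a clear margin. Compound 4 is therefore estimated to give 3, between 2.5 and 3.5, an expected step of a number 1.00 log units higher from compound 1 to compound 4 (beyond the scatter).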

Compound 4, distribution coefficient: 3
Compound 4: the middle estimate sits on the measured number at the digits printed; low and high end bracket the measured number.
By their numbers in this assay, from the lowest: compounds 1, 3 and 2 (each within the scatter of the next); then compound 4.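

In this assay, within the data shown here, 2-methylphenyl in place of 3-methylpyridin-2-yl gives a number 1.00 log units higher from compound 1 to compound 4 (beyond the scatter), whereas the one earlier step, at the end of the side chain, stayed within the scatter, so this position on the aromatic ring can shift the read-out clearly. Both groups hold 7 heavy atoms in a six-membered aromatic ring and differ in the ring nitrogen, a hydrogen-bond acceptor that 2-methylphenyl lacks, so the exchange of that nitrogen for carbon comes with the whole step. No measurement here accounts for the size of this step.

From the compounds shown here alone, whether a pyrimidine ring at this place would give a read-out on the same side of compound 1 remains open. So does the outcome of a chlorine in place of the methyl group on either ring.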